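From 2-bromobenzyl to 2-methoxybenzyl

A few compounds are considered here, and "the series" means these few. Any claim that something is new, unique, unknown or untested is made for them only; others in the source may bear on it.

Of the compounds shown here, three sharing one core have been tested in an ADME assay on NIH3T3 cells (Mus musculus) for cytotoxicity, with a stated time of 72 h; on this read-out higher numbers stand for weaker inhibition and lower numbers for stronger inhibition. Compound 1 (`OC[C@H]1O[C@@H](n2cnc3c(NCc4ccccc4F)ncnc32)[C@H](O)[C@@H]1O`) reads > 166000 nM, which is a limit. Compound 3 (`OC[C@H]1O[C@@H](n2cnc3c(NCc4ccccc4Br)ncnc32)[C@H](O)[C@@H]1O`) reads > 166000 nM, again only a limit. Compound 2 (`OC[C@H]1O[C@@H](n2cnc3c(NCc4ccc(F)cc4)ncnc32)[C@H](O)[C@@H]1O`) gives a true number, 44300 nM. Compound 4 (`COc1ccccc1CNc1ncnc2c1ncn2[C@@H]1O[C@H](CO)[C@@H](O)[C@H]1O`) has methoxy in place of bromo on an aromatic carbon, ortho to a large group: methoxy in place of bromo on an aromatic carbon. Among the compounds with values here, the closest precedent, a swap at that same place, is unreadable: a step that the two limits leave unreadable from compound 1 to compound 3. The readable steps, an at least 3.7-fold lower number from compound 1 to compound 2 (0.57 log units; beyond the scatter) and an at least 3.7-fold higher number from compound 2 to compound 3 (0.57 log units; beyond the scatter), both involve the 4-fluorophenyl of compound 2, which compound 4 lacks. No step beyond the scatter is therefore expected in this assay, and the estimated step is an at least 1.1-fold lower number from compound 3 to compound 4 (0.04 log units; that floor lies within the scatter). For compound 4 the expected value is 150000 nM, with an estimated range of 50000 nM to 300000 nM.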

Compound 4, half-maximal inhibitory concentration: 140000 nM
The estimate for compound 4 lay 1.1-fold (0.03 log units) above the measured number, within the range that was stated.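

With 2-methoxybenzyl at this position, the series gains a true number in this assay, and the steps read an at least 1.1-fold lower number from compound 3 to compound 4 (0.07 log units; that floor lies within the scatter) and an at least 1.1-fold lower number from compound 1 to compound 4 (0.07 log units; that floor lies within the scatter). Within the data shown here, both are only floors because one end of each is a limit: the limit of > 166000 nM in this assay, at which 2 of the 4 values shown sit. The one step here with true numbers at both ends is a 3.2-fold higher number from compound 2 to compound 4 (0.50 log units; beyond the scatter).

As far as these compounds go, it remains open how far compound 1 and compound 3 really lie from compound 4. Also open, from the compounds shown here alone, is whether an amine or a carboxylic acid at this place would give a step beyond the scatter.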